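Compound 3 against compound 2: formyl to carboxy

The source may hold more compounds than are shown below. What is called first, only, known or untested is meant among the compounds shown, and "the series" means these compounds.

Compound 1 `COC(OC)[C@@]1(C)CCC[C@@]2(C)[C@H]1CC=C(C)[C@@H]2CC/C(C)=C/CO`: > 50000 nM (a limit)
Compound 2 `CC1=CC[C@@H]2[C@](C)(CCC[C@]2(C)C=O)[C@H]1CC/C(C)=C/CO`: 29000 nM

Among the compounds with values here, in a functional assay on RAW264.7 cells (Mus musculus) for inhibition, read by Griess assay, with stated times of 2 h and 18 h (on this read-out higher numbers stand for weaker inhibition and lower numbers for stronger inhibition), compound 2 gives 29000 nM, the only true number so far. Compound 3 `CC1=CC[C@@H]2[C@](C)(CCC[C@]2(C)C(=O)O)[C@H]1CC/C(C)=C/CO` differs from compound 2 in one place: hydroxy in place of hydrogen on a carbonyl carbon. Within the data shown here, the one measured step touching this group, an at least 1.7-fold lower number from compound 1 to compound 2 (0.23 log units; that floor lies within the scatter), has a floor within the scatter, so it offers little guide to size or direction. No change beyond the scatter is therefore expected, and a 1.2-fold higher number from compound 2 to compound 3 (0.08 log units; within the scatter) is the estimated step. The expected value for compound 3 is 35000 nM, with an estimated range of 14000 nM to 85000 nM.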

Compound 3, half-maximal inhibitory concentration: 41100 nM
Beside the measured number, compound 3's estimate is 1.2-fold (0.07 log units) below it; the range from low to high includes it.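

At this saturated ring carbon, going from formyl to carboxy gives a 1.4-fold higher number from compound 2 to compound 3 (0.15 log units; within the scatter), so the two groups cannot be told apart in this read-out. Against dimethoxymethyl there is only an at least 1.2-fold lower number from compound 1 to compound 3 (0.08 log units; that floor lies within the scatter). That floor fixes no true size, because one end of the step rests on a limit: the limit of > 50000 nM in this assay, at which 1 of the 3 values shown sits.

Still open, going by these compounds, is whether any other group at this carbon, such as an amine, a methyl ester or a longer chain, would give a number clearly lower than these.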